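From a chlorine-bearing group to a bromine-bearing group

The source may hold more compounds than are shown below. What is called first, only, known or untested is meant among the compounds shown, and "the series" means these compounds.

Measured so far in a functional assay on HepG2 cells (Homo sapiens) for antiproliferative activity, read by MTT assay, with a stated time of 72 h (a higher number here means a weaker inhibitor, a lower number a stronger inhibitor), both values being limits:
Compound 1 `O=C1O/C(=C\Cn2cnc3cc[nH]c3c2=O)C(OCc2ccccc2)=C1OCc1ccccc1`: > 100000 nM
Compound 2 `O=C1O/C(=C\Cn2cnc3ccnc(Cl)c32)C(OCc2ccccc2)=C1OCc1ccccc1`: > 100000 nM

Compound 2 stands at > 100000 nM, which is a limit and not a number. Both measured compounds share the same reading: the limit of > 100000 nM in this assay, at which 2 of the 2 values shown sit.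

Compound 3 `O=C1O/C(=C\Cn2cnc3ncc(Br)c-3c2)C(OCc2ccccc2)=C1OCc1ccccc1` differs from compound 2 in one place: a group of 10 heavy atoms (6 carbon, 3 nitrogen, 1 bromine; one five-membered aromatic ring with 1 hetero atom, one six-membered aromatic ring with 2 hetero atoms) in place of a group of 10 heavy atoms (6 carbon, 3 nitrogen, 1 chlorine; one five-membered aromatic ring with 2 hetero atoms, one six-membered aromatic ring with 1 hetero atom), on a saturated chain carbon bound to a double-bonded chain carbon. The entering group carries 1 bromine where the leaving group carries 1 chlorine, and its six-membered aromatic ring has 2 hetero atoms rather than 1 hetero atom.

Among the measured compounds shown here, only one measured step bears on this change: a step that the two limits leave unreadable from compound 1 to compound 2. It exchanges groups of the same two ring types, but it has no readable size to carry over. The limit of compound 2 at > 100000 nM gives no starting number either. No readable step is therefore expected in this assay, and no direction can be given. The expected outcome is a number no higher from compound 2 to compound 3 (the limit leaves the size open). For compound 3 the estimated value is 100000 nM, with an expected range from 30000 nM to 300000 nM.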

Compound 3, half-maximal inhibitory concentration: > 100000 nM
Compound 3: no number, only a limit; the forecaster's own chance of this, stated with the estimate: 70%; the middle value sits exactly at the limit.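

In this assay compound 3 gives > 100000 nM, which is a limit and not a number. No step among compound 1, compound 2 and compound 3 can be read, since all three share one reading: the limit of > 100000 nM in this assay, at which 3 of the 3 values shown sit.

The compounds shown leave open how the bromine-bearing group truly compares with the chlorine-bearing group, and which change, if any, would give a readable number.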